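Fluoro for Hydroxy Where the Measured Step Is Unreadable

A few compounds are considered here, and "the series" means these few. Any claim that something is new, unique, unknown or untested is made for them only; others in the source may bear on it.

Compound 3 `CS(=O)(=O)Nc1ccc(O)c2c1CCCC2c1c[nH]cn1` carries a hydroxy group, and in an assay on isolated protein for binding affinity to Alpha-1D adrenergic receptor (Rattus norvegicus), read by radioligand binding (a higher number here means a weaker inhibitor, a lower number a stronger inhibitor), compound 3 gives < 10000 nM, which is a limit of the assay and not a number. The chloro analogue compound 1 `CS(=O)(=O)Nc1ccc(Cl)c2c1CCCC2c1c[nH]cn1` gives 2880 nM in this assay. Compound 2 `CCS(=O)(=O)Nc1cccc2c1CCCC2c1c[nH]c(C)n1` gives < 10000 nM in this assay, again a limit. Going by the values given here, the only step touching this position, a step that the limit leaves unreadable from compound 1 to compound 3, is left unsized since the limit of < 10000 nM in this assay, at which 2 of the 3 values shown sit, governs the value of compound 3. Compound 4 `CS(=O)(=O)Nc1ccc(F)c2c1CCCC2c1c[nH]cn1` differs from compound 3 by fluoro in place of hydroxy on an aromatic carbon. Among the compounds with values here, no measured step on a fluoro group exists, so the expectation leans on compound 1 and its value of 2880 nM for a halogen at this place. Compound 4 is therefore estimated at 4000 nM, between 1200 nM and 13000 nM, a step that the limit leaves unreadable from compound 3 to compound 4 whose direction the limit leaves open.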

Compound 4, inhibition constant: 3020 nM
Estimate against measurement, compound 4: 1.3-fold (0.12 log units) above, within the range that was stated.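

In this assay, going by these compounds alone, the change of chloro to fluoro on this aromatic carbon gives a 1.0-fold higher number from compound 1 to compound 4 (0.02 log units; within the scatter), the first readable step at this position, and it shows that these two halogens cannot be told apart here. The steps involving compound 3 cannot be read, since its value is a limit of the assay and not a number: the limit of < 10000 nM in this assay, at which 2 of the 4 values shown sit.

From the compounds shown here alone, what a methoxy group or an amine at this place would give stays open. Also open, going by these compounds, is whether any group here reaches a value clearly apart from those of compound 1 and compound 4.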